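A Urea Variation Tested for Antiproliferative Effect

The compounds below may be only part of what the source reports. "The series", "measured", "known", "first", "only" and "open" are said of these compounds alone.

The account follows the step from compound 2 `COC(=O)c1cc(=O)c2cc(NC(=O)Nc3ccc(F)c(Cl)c3)ccc2[nH]1` to compound 3 `COC(=O)c1cc(=O)c2cc(NC(=O)Nc3ccc4c(c3)CCC4)ccc2[nH]1` in an ADME assay on BJ cells (Homo sapiens) for antiproliferative activity, with a stated time of 72 h; on this read-out lower numbers stand for an effect already at smaller amounts and higher numbers for an effect only at larger amounts of compound. Two measured compounds frame the picture. Compound 1 `COc1ccc(-c2cc(=O)c3c(OC)cc(OC)cc3n2S(=O)(=O)c2c(F)c(F)c(F)c(F)c2F)cc1` reaches only a limit of the assay in this assay, where compound 1 gives > 34400 nM. Compound 2 likewise reaches only a limit of the assay, giving > 12600 nM in this assay. Compound 2 thus stands at the limit of > 12600 nM in this assay, at which 1 of the 2 values shown sits, and carries no number, while the other measured compound sits at the limit of > 34400 nM in this assay, at which 1 of the 2 values shown sits. Among the compounds with values here, no step between two measured compounds is available, so nothing shows how any structural change moves this read-out. The change from compound 2 to compound 3 is 2,3-dihydro-1H-inden-5-yl in place of 3-chloro-4-fluorophenyl on an amide-type nitrogen. With compound 2 resting at a limit, no direction can be read from the data for this change. The step that the limit leaves unreadable from compound 2 to compound 3 is expected to be none beyond the scatter. Compound 3 is therefore estimated at 15000 nM, with a range from 5000 nM to 50000 nM. It is expected that compound 3 will most likely again be reported only as a limit rather than as a number.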

Compound 3, half-maximal effective concentration: > 24100 nM
Compound 3: no number, only a limit; the forecaster's own chance of this, stated with the estimate: 75%; middle value at least 1.6-fold (0.20 log units) away from the limit.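

Within the data shown here, compound 2 and compound 3 both reach only a limit of the assay in this assay, so the change between them yields no step that can be read. The compounds shown leave open how any structural change moves this read-out, as all three stand at limits and none carries a number.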